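Adding a Methyl Group to the Phenyl Ring

The source may hold more compounds than are shown below. What is called first, only, known or untested is meant among the compounds shown, and "the series" means these compounds.

For the measured compounds named here, compound 3 `Cc1nnc(SCC(=O)N/N=c2/scc(-c3ccccc3)n2-c2ccccc2)s1` was tested in a functional assay on C6 cells (Rattus norvegicus) for cytotoxicity, read by MTT assay, with a stated time of 24 h, tested at 200 ug/mL (on this read-out lower numbers stand for a stronger effect and higher numbers for a weaker effect at the one concentration tested), where compound 3 gives 59.2%, the highest of the three numbers measured so far. Compound 1 `Cc1nnc(SCC(=O)N/N=c2/scc(-c3ccc(Cl)cc3)n2-c2ccccc2)s1` gives 29%, and compound 2 `Cc1ccc(-c2cs/c(=N/NC(=O)CSc3nncn3C)n2-c2ccccc2)cc1` gives 27.8%. Going by the values given here, only one pair differs in a single place: a number 30.2 percentage points higher from compound 1 to compound 3 (beyond the scatter), so removing a chloro group raised the number by a large amount, meaning a weaker effect.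

Compound 4 `Cc1ccc(-c2cs/c(=N/NC(=O)CSc3nnc(C)s3)n2-c2ccccc2)cc1` has not yet been measured. It differs from compound 3 by methyl in place of hydrogen on an aromatic carbon. Among the compounds with values here, no measured step shows exactly this change. The step from compound 1 to compound 3 suggests that a group on this ring goes with a lower number, and compound 2, which carries such a methyl group but also differs elsewhere, gives 27.8%, a low number too.

Compound 4 is therefore expected to give about 35%, estimated to lie between 22% and 55%. The expected step is a number 24.2 percentage points lower from compound 3 to compound 4 (beyond the scatter), a drop beyond the scatter but less certain than the measured one.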

Compound 4, a percentage reported as activity, at one concentration (the size of the read-out at that concentration, not a potency): 13.3%
Beside the measured number, compound 4's estimate is 21.7 percentage points above it; the measured number lies below the stated range.
By their numbers in this assay, from the lowest: compound 4; then compounds 2 and 1 (each within the scatter of the next); then compound 3.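

In this assay, the change from phenyl to 4-methylphenyl gives the largest single-place step seen so far, a number 45.9 percentage points lower from compound 3 to compound 4 (beyond the scatter), so this position can strongly change the read-out with the addition of just one carbon. Chloro and methyl also differ here, with a number 15.7 percentage points lower from compound 1 to compound 4 (beyond the scatter), so the result depends on which group is present, not only on whether the position is substituted; the group on the sulfur matters too, with a number 14.5 percentage points lower from compound 2 to compound 4 (beyond the scatter). The data shown offer no explanation for these differences.

On these data alone, it remains open whether an ethyl group, a methoxy group, an amine or a carboxylic acid at this position would lower the number further or reverse the effect. A single concentration also leaves the potency of these compounds unknown.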